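Moving a Nitro Group: Compound 2 to Compound 4

The compounds below may be only part of what the source reports. "The series", "measured", "known", "first", "only" and "open" are said of these compounds alone.

Of the compounds shown here, three sharing one core have been measured in a functional assay on the whole organism with Rattus norvegicus as the target, at a dose of 20 mg/kg by the intraperitoneal route; a higher number here means more inhibition at the dose given (going by the name of the read-out), a lower number less inhibition. Compound 1 `Nc1nc(N)nc(-c2cc(F)ccc2Cl)n1` gives 78%, compound 2 `Nc1nc(N)nc(-c2cccc(F)c2)n1` gives 70%, and compound 3 `Nc1nc(N)nc(-c2ccccc2[N+](=O)[O-])n1` gives 11%. Compound 2 therefore stands second of the three, within the scatter of compound 1 and far above compound 3.

The next compound, compound 4 `Nc1nc(N)nc(-c2cccc([N+](=O)[O-])c2)n1`, differs from compound 2 by nitro in place of fluoro on an aromatic carbon. Among the compounds with values here, the only measured step that touches a substituent on this ring is the one from compound 1 to compound 2, a number 8 percentage points lower from compound 1 to compound 2 (within the scatter), which removed a halogen without a clear effect. Within the data shown here, no measured step exchanges fluoro for nitro. Among the measured compounds shown here, what the numbers show is that compound 3, the only compound carrying a nitro group, albeit differently placed, sits well below compound 2 in this assay.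

Weighing the small halogen step against the low reading of compound 3, compound 4 is expected to fall to about 35%, between 10% and 65%, an estimated step of a number 35 percentage points lower from compound 2 to compound 4 (beyond the scatter).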

Compound 4, a percentage reported as inhibition, in the whole organism at one dose (the size of the read-out at that dose, not a potency): 85%
The estimate for compound 4 lay 50 percentage points below the measured number; the measured number lies above the stated range.
By their numbers in this assay, from the lowest: compound 3; then compounds 2, 1 and 4 (each within the scatter of the next, the first and the last beyond it).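

In this assay, this position on the ring accepts a larger group without any loss: nitro, with 3 heavy atoms, replaces fluoro, with 1, and the exchange gives a number 15 percentage points higher from compound 2 to compound 4 (beyond the scatter), a modest rise. A nitro group on the ring therefore does not by itself go with a low reading, since compound 3, with its nitro group placed differently, gives 11% while compound 4 gives 85% in the same test. Nothing available here explains the rise or that gap.

From the compounds shown here alone, whether an amine or a carboxylic acid at this same position would hold the reading remains open. So does the effect of adding a chloro group to compound 4, the change that in the fluoro series separates compound 2 from compound 1.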